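The source may report more compounds than this note shows. Statements on the series, on what has been measured and on what is new or still open speak of the compounds shown alone.

Measured in a functional assay on the whole organism with Mus musculus as the target; on this read-out higher numbers stand for an effect only at larger amounts of compound and lower numbers for an effect already at smaller amounts:
- compound 1 `NC(=O)/C=C1\CCc2c(F)cc(F)cc21`: 69 mg/kg
- compound 2 `O=C(/C=C1\CCc2c(F)cc(F)cc21)NCCO`: 100 mg/kg

Compound 2 has a single neighbour on these numbers, compound 1, and the two lie within the scatter of each other. Compound 3 `CC(C)NC(=O)/C=C1\CCc2c(F)cc(F)cc21` carries isopropyl in place of 2-hydroxyethyl on an amide-type nitrogen. For the measured compounds named here, the only measured step at this nitrogen, 2-hydroxyethyl in place of hydrogen, is a 1.4-fold higher number from compound 1 to compound 2 (0.16 log units; within the scatter). Going by the values given here, with one small step as the sole guide, no change beyond the scatter is expected, and the expected step is a 1.3-fold lower number from compound 2 to compound 3 (0.12 log units; within the scatter). The estimate for compound 3 is 75 mg/kg, with an expected range of 30 mg/kg to 180 mg/kg.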

Compound 3, dose for half-maximal effect: 50 mg/kg
For compound 3 the middle estimate is 1.5-fold (0.18 log units) above the measured one, within the range that was stated.
By their numbers in this assay, from the lowest: compounds 3, 1 and 2 (each within the scatter of the next).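

In this assay isopropyl in place of 2-hydroxyethyl gives a 2.0-fold lower number from compound 2 to compound 3 (0.30 log units; within the scatter) and isopropyl in place of hydrogen gives a 1.4-fold lower number from compound 1 to compound 3 (0.14 log units; within the scatter) on the amide-type nitrogen. Losing the hydrogen-bond donor and acceptor of 2-hydroxyethyl thus brings no change beyond the scatter, and neither does an all-carbon group in place of the amide hydrogen. No available evidence explains these numbers.

On these data alone, whether a benzyl group or a longer chain at this nitrogen would move the number beyond the scatter stays open. So does the effect of a chain ending in an amine or a carboxylic acid.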